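The compounds below may be only part of what the source reports. "The series", "measured", "known", "first", "only" and "open" are said of these compounds alone.

Measured so far:
compound 1 `NS(=O)(=O)c1ccc(NC(=O)CSc2nnc(COc3ccc4ccccc4c3)n2Cc2ccccc2)cc1` — 94.5 ug/mL
compound 2 `O=C(CSc1nnc(COc2ccc3ccccc3c2)n1Cc1ccccc1)Nc1ccc(Cl)cc1` — >= 4.93 ug/mL

In a toxicity assay on MT4 cells (Homo sapiens) for cytotoxicity, read by MTT assay, with a stated time of 5 days (on this read-out lower numbers stand for higher toxicity in this test and higher numbers for lower toxicity in this test), compound 1 `NS(=O)(=O)c1ccc(NC(=O)CSc2nnc(COc3ccc4ccccc4c3)n2Cc2ccccc2)cc1` gives 94.5 ug/mL. For compound 2 `O=C(CSc1nnc(COc2ccc3ccccc3c2)n1Cc1ccccc1)Nc1ccc(Cl)cc1` the reading in this assay is a limit, >= 4.93 ug/mL, and not a number. Among the compounds with values here, the single measured step, a step that the limit leaves unreadable from compound 1 to compound 2, cannot be read in size because of the limit of >= 4.93 ug/mL in this assay, at which 1 of the 2 values shown sits. Within the data shown here, compound 2 therefore stands only as a range in this assay, with no step of readable size attached to it.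

Compound 3 `CCOC(=O)c1ccc(NC(=O)CSc2nnc(COc3ccc4ccccc4c3)n2Cc2ccccc2)cc1` differs from compound 2 by ethoxycarbonyl in place of chloro on an aromatic carbon. Among the measured compounds shown here, no measured step bears on this change with a readable size; the one step runs to a limit. For the measured compounds named here, the expectation for this assay is therefore open in direction, with compound 1 as the only full number for orientation. Compound 3 is estimated at 60 ug/mL, with an expected range from 10 ug/mL to 200 ug/mL. The step this implies, a step that the limit leaves unreadable from compound 2 to compound 3, is an expectation rather than a reading.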

Compound 3, half-maximal cytotoxic concentration: >= 90.7 ug/mL
Compound 3 ended at the assay's limit (the forecaster's own chance of this, stated with the estimate: 40%); middle value at least 1.5-fold (0.17 log units) from the limit.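

Compound 3 reads >= 90.7 ug/mL, which is a limit and not a number, so no new step can be read between compound 3 and either compound 1 or compound 2. The compounds shown leave open whether sulfamoyl, chloro and ethoxycarbonyl differ at all in this assay.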